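The source may report more compounds than this note shows. Statements on the series, on what has been measured and on what is new or still open speak of the compounds shown alone.

In a functional assay on HT-29 cells (Homo sapiens) for cytotoxicity, read by MTT assay, with a stated time of 72 h (a higher number here means a weaker inhibitor of growth, a lower number a stronger inhibitor of growth), three compounds have been measured so far:

compound 1, `N#C[Se]c1ccc(NC(=O)Oc2ccc(F)cc2)cc1`: 8800 nM
compound 2, `C=CCOC(=O)Nc1ccc([Se]C#N)cc1`: 24500 nM
compound 3, `N#C[Se]c1ccc(NC(=O)Oc2ccccc2)cc1`: 11700 nM

Compound 3 stands second highest of these three numbers. Its nearest neighbour is compound 1, and the step of a 1.3-fold higher number from compound 1 to compound 3 (0.12 log units; within the scatter) shows that hydrogen in place of fluoro on an aromatic carbon left the number essentially unchanged. Its furthest neighbour is compound 2, and the step of a 2.1-fold lower number from compound 2 to compound 3 (0.32 log units; beyond the scatter), phenyl in place of allyl on an oxygen next to a carbonyl group, is modest but beyond the scatter.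

Compound 4, `N#C[Se]c1ccc(NC(=O)Oc2ccc(Cl)cc2)cc1`, has not yet been measured. It differs from compound 3 in a single place: chloro in place of hydrogen on an aromatic carbon

Within the data shown here, the one measured step that speaks to this aromatic carbon is a 1.3-fold higher number from compound 1 to compound 3 (0.12 log units; within the scatter), where a halogen at the same aromatic carbon made no difference beyond the scatter. On that basis the chloro in compound 4 is expected to move the number little, and the step of a 1.2-fold lower number from compound 3 to compound 4 (0.09 log units; within the scatter) is expected to fall within the scatter, if anything toward a slightly lower number. Compound 4 is therefore estimated at 9500 nM, with a range from 4500 nM to 20000 nM.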

Compound 4, concentration for 50% growth inhibition: 11800 nM
For compound 4 the middle estimate is 1.2-fold (0.09 log units) below the measured one, within the range that was stated.
By their numbers in this assay, from the lowest: compounds 1, 3 and 4 (each within the scatter of the next); then compound 2.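

With chloro as well as fluoro now set against hydrogen, the aromatic carbon para to a large group has carried three different substituents in this assay, and none of the comparisons separates them: chloro in place of hydrogen gives a 1.0-fold higher number from compound 3 to compound 4 (0.00 log units; within the scatter), and chloro in place of fluoro gives a 1.3-fold higher number from compound 1 to compound 4 (0.13 log units; within the scatter). The earlier compounds shown here offered only one halogen at this carbon, so they could not show that a second halogen, with its different heavy atom, would also leave the number within the scatter of the compound carrying hydrogen. The only step beyond the scatter among these compounds remains the change on the oxygen next to the carbonyl group, a 2.1-fold lower number from compound 2 to compound 3 (0.32 log units; beyond the scatter), and no measurement offered here gives a reason for the flat result at the aromatic carbon.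

The compounds shown cannot tell whether this carbon would stay as undemanding with a group other than a halogen, such as a methoxy group, an amine or a carboxylic acid. They also leave open whether a heavier halogen, such as bromo, would behave as chloro and fluoro do here.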